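The source may hold more compounds than are shown below. What is called first, only, known or untested is meant among the compounds shown, and "the series" means these compounds.

Measured in a functional assay on Z-138 cells (Homo sapiens) for antiproliferative activity, with a stated time of 72 h; a lower number here means a stronger inhibitor, a higher number a weaker inhibitor:
compound 1 `Nc1ncnn2c([C@@H]3O[C@H](CO)[C@@H](O)[C@H]3O)cc(C#Cc3ccccc3)c12`: 41400 nM
compound 2 `Nc1ncnn2c([C@@H]3O[C@H](CO)[C@@H](O)[C@H]3O)cc(-c3ccccc3)c12`: > 100000 nM, a limit
compound 3 `Nc1ncnn2c([C@@H]3O[C@H](CO)[C@@H](O)[C@H]3O)cc(-c3ccc(F)cc3)c12`: > 100000 nM, a limit

Compound 3 has no numerical value in this assay. Compound 3 stands only at a limit, > 100000 nM. The same is true of compound 2, so the data contain (the limit of > 100000 nM in this assay, at which 2 of the 3 values shown sit). Compound 1 is the only one of the three with a measured number.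

The next compound, compound 4 `Nc1ncnn2c([C@@H]3O[C@H](CO)[C@@H](O)[C@H]3O)cc(-c3ccc(F)cc3F)c12`, changes 4-fluorophenyl to 2,4-difluorophenyl: fluoro in place of hydrogen on an aromatic carbon. The new fluoro sits on an aromatic carbon, ortho to a large group and meta to a fluoro group.

Going by the values given here, the closest precedent is the same kind of exchange, fluoro in place of hydrogen on an aromatic carbon, and it gives a step that the two limits leave unreadable from compound 2 to compound 3. The other two steps, an at least 2.4-fold higher number from compound 1 to compound 2 (0.38 log units; beyond the scatter) and an at least 2.4-fold higher number from compound 1 to compound 3 (0.38 log units; beyond the scatter), replace 2-phenylethynyl, which is a different change and says little about adding a fluoro. Among the compounds with values here, no measured step therefore points to a gain or a loss here, and no readable shift is expected. The expected change is a number no higher from compound 3 to compound 4 (the limit leaves the size open). Compound 4 will most likely also be reported only as a limit. Compound 4 is estimated at 100000 nM. The expected range for compound 4 runs from 50000 nM to 200000 nM.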

Compound 4, half-maximal inhibitory concentration: 59100 nM
For compound 4 the middle estimate is 1.7-fold (0.23 log units) above the measured one; the measured number falls inside the stated range.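

Adding the fluoro ortho to a large group turns a limit into a number in this assay: the change gives an at least 1.6-fold lower number from compound 3 to compound 4 (0.22 log units; that floor lies within the scatter). Going from the unsubstituted phenyl to 2,4-difluorophenyl reads the same way, with an at least 1.6-fold lower number from compound 2 to compound 4 (0.22 log units; that floor lies within the scatter), and neither step shows a gain beyond the scatter, while the true size of both stays open because each starts from a limit: the limit of > 100000 nM in this assay, at which 2 of the 4 values shown sit. The new comparison is with 2-phenylethynyl, where a 1.4-fold higher number from compound 1 to compound 4 (0.15 log units; within the scatter) places 2,4-difluorophenyl and 2-phenylethynyl level within the scatter, so a group other than 2-phenylethynyl at this position can also give a measured number in this assay, though compound 1 and compound 4 both remain weak inhibitors on these cells.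

As far as these compounds go, it stays open whether one fluoro at the ortho place, as a 2-fluorophenyl group, is enough to give a measured number, or whether both fluoro groups of compound 4 are needed. From the compounds shown here alone, it also stays open whether a methoxy group or an amine on the same phenyl ring would move the number beyond the scatter.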